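The compounds below may be only part of what the source reports. "The series", "measured", "known", "first", "only" and "open" are said of these compounds alone.

Measured so far:
compound 1, `COC(=O)[C@@]1(C)CCC=C2[C@@H]1CC[C@@H](C)[C@]2(C)Cc1c[nH]c2ccc(OC)cc12`: 5700 nM in a functional assay on WiDr cells (Homo sapiens) for inhibition, read by sulforhodamine B assay, with a stated time of 48 h; a lower number here means a stronger inhibitor of growth, a higher number a weaker inhibitor of growth
compound 2, `COC(=O)[C@@]1(C)CCC=C2[C@@H]1CC[C@@H](C)[C@]2(C)Cc1c(C)[nH]c2ccccc12`: 19000 nM
compound 3, `COC(=O)[C@@]1(C)CCC=C2[C@@H]1CC[C@@H](C)[C@]2(C)Cc1c(C)[nH]c2ccc(OC)cc12`: 17000 nM

Compound 1 and compound 3 differ in one place, (methyl in place of hydrogen on an aromatic carbon), and that change gave a 3.0-fold higher number from compound 1 to compound 3 (0.47 log units; beyond the scatter). Compound 2 and compound 3 differ by a methoxy in place of hydrogen on an aromatic carbon, with a 1.1-fold lower number from compound 2 to compound 3 (0.05 log units; within the scatter). How the core of compound 1 and the core of compound 2 differ is not broken down here.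

Compound 4, `COC(=O)[C@@]1(C)CCC=C2[C@@H]1CC[C@@H](C)[C@]2(C)Cc1c(C)[nH]c2c(C)cccc12`, has not been measured. It differs from compound 2 by methyl in place of hydrogen on an aromatic carbon. This is the same kind of change as from compound 1 to compound 3, but not the same: there the methyl entered a five-membered aromatic ring with one nitrogen, next to the ring nitrogen and next to the ring atom that bears a large group, whereas here it enters a six-membered aromatic ring of carbon only, ortho to a fused ring and meta to a fused ring. Within the data shown here, the step from compound 2 to compound 4 is expected to be smaller than the earlier one, roughly a 1.2-fold higher number from compound 2 to compound 4 (0.06 log units; within the scatter), because a 1.1-fold lower number from compound 2 to compound 3 (0.05 log units; within the scatter) was the only change measured on that same ring and stayed within the scatter. Compound 4 is therefore expected to give about 22000 nM in this assay, most likely between 9000 nM and 55000 nM.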

Compound 4, concentration for 50% growth inhibition: 21000 nM
Estimate against measurement, compound 4: 1.0-fold (0.02 log units) above; low and high end bracket the measured number.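

Putting a methyl in place of a hydrogen on an aromatic carbon of the six-membered aromatic ring of carbon only gave a 1.1-fold higher number from compound 2 to compound 4 (0.04 log units; within the scatter) in this assay, so this step made no readable difference to growth inhibition. The same kind of change therefore does not carry a fixed size from one core to another in this series: the same change on two cores in this assay, a 3.0-fold higher number (0.47 log units; beyond the scatter) from compound 1 to compound 3 and a 1.1-fold higher number (0.04 log units; within the scatter) from compound 2 to compound 4, 2.7-fold (0.43 log units) apart, beyond the scatter of two such steps. This does not show why the two steps differ, since the methyl sits on a different ring in each pair and the cores differ as well, and two steps cannot separate the effect of the place from that of the core.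

The aromatic rings shown carry only hydrogen, methyl and methoxy, so what an amine, a carboxylic acid or a longer chain would do there remains open. Also open, as far as these compounds go, is whether a methyl at other positions on the six-membered ring would again leave the number unchanged.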